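A few compounds are considered here, and "the series" means these few. Any claim that something is new, unique, unknown or untested is made for them only; others in the source may bear on it.

Among the compounds with values here, compound 2 `O=c1[nH]c2ncn(Cc3ccccc3)c2c(=O)n1O` gives 10400 nM in an assay on isolated protein for inhibition of CCR4-NOT transcription complex subunit 7 (Homo sapiens), read by fluorescence (on this read-out lower numbers stand for stronger inhibition and higher numbers for weaker inhibition), the lowest of the two numbers so far; compound 1 `O=c1[nH]c2ncn(Cc3ccncc3)c2c(=O)n1O` gives 23300 nM in this assay. Within the data shown here, the only measured step, a 2.2-fold lower number from compound 1 to compound 2 (0.35 log units; beyond the scatter), bears on the change to compound 3 `O=c1[nH]c2ncn(Cc3ccccn3)c2c(=O)n1O`, which is pyridin-2-yl in place of phenyl on a saturated chain carbon bound to an aromatic nitrogen. Because a pyridine ring in place of phenyl gave a higher number in reverse in a 2.2-fold lower number from compound 1 to compound 2 (0.35 log units; beyond the scatter), a modest rise in this assay is expected, and the step is estimated as a 1.7-fold higher number from compound 2 to compound 3 (0.24 log units; within the scatter). Compound 3 is therefore expected to give about 18000 nM in this assay, within a range from 8000 nM to 40000 nM.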

Compound 3, half-maximal inhibitory concentration: 10600 nM
Compound 3: the middle estimate sits 1.7-fold (0.23 log units) above what was measured; the measured number falls inside the stated range.
By their numbers in this assay, from the lowest: compounds 2 and 3 (each within the scatter of the next); then compound 1.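

In this assay a ring nitrogen alone changes little at this position, on a saturated chain carbon bound to an aromatic nitrogen: pyridin-2-yl in place of phenyl gives no step beyond the scatter (a 1.0-fold higher number from compound 2 to compound 3 (0.01 log units; within the scatter)). The place of the nitrogen within the ring does matter, since pyridin-2-yl in place of pyridin-4-yl gives a modest step (a 2.2-fold lower number from compound 1 to compound 3 (0.34 log units; beyond the scatter)). Nothing on hand explains this difference. Still open, from the compounds shown here alone, is what pyridin-3-yl, an amine or carboxylic acid on the phenyl ring, or a longer chain would give.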